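The compounds below may be only part of what the source reports. "The series", "measured", "known", "first", "only" and "open" are said of these compounds alone.

Compound 1 `O=C(O)CCCCCCCCCn1nc(-c2ccccc2)c(-c2ccccc2)c1-c1ccccc1` carries three phenyl groups on its core and a nine-carbon chain ending in carboxymethyl. Among the measured compounds shown here, in a functional assay for inhibition, with Homo sapiens as the target (on this read-out higher numbers stand for weaker inhibition and lower numbers for stronger inhibition), compound 1 gives 5500 nM, the only definite number among the three measured compounds. Compound 2 `O=C(O)CCCCCCCCn1cc(-c2ccccc2)cn1` reaches only the limit > 105000 nM in this assay. Compound 3 `O=C(O)CCCCCCCCCn1cc(-c2ccccc2)c(-c2ccccc2)n1` likewise reaches only the limit > 81000 nM in this assay. For the measured compounds named here, the one measured step that differs in a single place, an at least 14-fold higher number from compound 1 to compound 3 (1.16 log units; beyond the scatter), can be given only as a lower bound because of the limit of > 81000 nM in this assay, at which 1 of the 3 values shown sits; it shows that removing one of the phenyl groups weakens inhibition markedly.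

Compound 4 `CS(=O)(=O)NC(=O)CCCCCCCCn1nc(-c2ccccc2)c(-c2ccccc2)c1-c1ccccc1` keeps all three phenyl groups and the same chain and changes only the chain end: (methylsulfonyl)carbamoyl in place of carboxymethyl on a saturated chain carbon, eight bonds along the chain from an aromatic nitrogen. Going by the values given here, no measured step touches this part of the molecule, so the phenyl-removal step offers no guide to it, and no change beyond the usual scatter is expected. The step from compound 1 to compound 4 is therefore estimated as no change at the digits printed from compound 1 to compound 4 (within the scatter). Compound 4 is expected to give about 5500 nM in this assay, within a range from 1500 nM to 20000 nM.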

Compound 4, half-maximal inhibitory concentration: 5900 nM
Estimate against measurement, compound 4: 1.1-fold (0.03 log units) below; measured number inside the range.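

Among the compounds shown here, this is the first measured step at the chain end, and in this assay it reads a 1.1-fold higher number from compound 1 to compound 4 (0.03 log units; within the scatter). The chain end therefore accepts (methylsulfonyl)carbamoyl in place of carboxymethyl, with 7 heavy atoms instead of 4 and 3 hydrogen-bond acceptors instead of 1, without a change beyond the scatter, whereas the change on the core in an at least 14-fold higher number from compound 1 to compound 3 (1.16 log units; beyond the scatter) lies beyond it. The compounds shown give no measured property that could explain why this larger chain end leaves the read-out in place.

On these data alone, it remains open whether quite different chain ends, such as an amine or a primary amide, or a longer chain carrying the same (methylsulfonyl)carbamoyl, would also leave the number within the scatter of compound 1. It is also unknown whether this chain-end change would behave the same way on a core with fewer phenyl groups, where the values shown for the carboxymethyl compounds are only limits.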